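Sulfonamide heteroaryl swap carried over to a second core

The compounds below may be only part of what the source reports. "The series", "measured", "known", "first", "only" and "open" are said of these compounds alone.

Compound 1 `O=C1/C(=C/c2coc3ccccc3c2=O)N=C(c2ccc(Cl)cc2)N1c1ccc(S(=O)(=O)Nc2ncccn2)cc1` and compound 2 `O=C1/C(=C/c2coc3ccccc3c2=O)N=C(c2ccc(Cl)cc2)N1c1ccc(S(=O)(=O)Nc2nccs2)cc1` share one core, while compound 3 `O=c1c(CNc2ccc(S(=O)(=O)Nc3ncccn3)cc2)coc2ccccc12` and compound 4 `O=c1c(CNc2ccc(S(=O)(=O)Nc3nccs3)cc2)coc2ccccc12` share another; the difference between the two cores is not broken down here. In a functional assay on A549 cells (Homo sapiens) for cytotoxicity, read by sulforhodamine B assay, with a stated time of 72 h (on this read-out lower numbers stand for stronger inhibition and higher numbers for weaker inhibition), compound 1 gives 59000 nM. Compound 2 reaches only a limit of this assay, > 100000 nM. The change from compound 1 to compound 2 is 1,3-thiazol-2-yl in place of pyrimidin-2-yl on a sulfonamide nitrogen, and it produced an at least 1.6-fold higher number from compound 1 to compound 2 (0.22 log units; that floor lies within the scatter), the size of that step being bounded by the limit of > 100000 nM in this assay, at which 1 of the 3 values shown sits. In this assay compound 3 gives 85300 nM, a number within the scatter of that for compound 1. Compound 4 carries the same change on its core, (1,3-thiazol-2-yl in place of pyrimidin-2-yl on a sulfonamide nitrogen), at the same place on the sulfonamide nitrogen. The step expected here is a 1.6-fold higher number from compound 3 to compound 4 (0.22 log units; within the scatter) because the same change gave an at least 1.6-fold higher number from compound 1 to compound 2 (0.22 log units; that floor lies within the scatter) on the other core, and the starting number for compound 3 already stands close to the limit. For compound 4 the estimated number in this assay is 140000 nM, expected to fall between 70000 nM and 300000 nM, with a fair chance that only a limit is recorded.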

Compound 4, half-maximal inhibitory concentration: 25600 nM
For compound 4 the middle estimate is 5.5-fold (0.74 log units) above the measured one, outside the stated range (below it).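

In this assay, 1,3-thiazol-2-yl in place of pyrimidin-2-yl on a sulfonamide nitrogen gives a 3.3-fold lower number from compound 3 to compound 4 (0.52 log units; beyond the scatter), so the step seen on the core of compound 1 does not predict the step on the core of compound 3. In this series the same change cannot be carried from one core to the other with its sign and size intact: the same change on two cores in this assay, an at least 1.6-fold higher number (0.22 log units; that floor lies within the scatter) from compound 1 to compound 2 and a 3.3-fold lower number (0.52 log units; beyond the scatter) from compound 3 to compound 4, at least 5.6-fold (0.75 log units) apart, beyond the scatter of two such steps. The four compounds do not show why the two steps part, and the size of the step on the core of compound 1 remains bounded: the limit of > 100000 nM in this assay, at which 1 of the 4 values shown sits.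

Only one pair per core is shown, and the two cores are not broken down into their parts, so which part of the core difference goes with the gap remains open. A pyridin-2-yl group on a sulfonamide nitrogen, set on both cores, would give a third pair to compare with these two.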